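Arylidene series: methyl for bromo-fluoro on the pendant ring

The compounds below may be only part of what the source reports. "The series", "measured", "known", "first", "only" and "open" are said of these compounds alone.

Compound 1 `C=CCn1c(=O)/c(=C\c2cccc(Cl)c2Cl)[nH]c(=O)/c1=C\c1ccccc1OC` and compound 2 `C=CCn1c(=O)/c(=C\c2ccc(F)c(Br)c2)[nH]c(=O)/c1=C\c1ccccc1OC` share one core with an allyl group and a 2-methoxyphenyl arm, differing only in the second aryl ring. In a functional assay on MOLT-4 cells (Homo sapiens) for cytotoxicity, read by CCK-8 assay, with a stated time of 72 h (on this read-out lower numbers stand for stronger inhibition and higher numbers for weaker inhibition), compound 1 gives 1200 nM. Within the data shown here, compound 2 is recorded in this assay as "not active" (no number reported), so no single number stands for it and no step to compound 1 can be sized. Compound 3 `C=CCn1c(=O)/c(=C\c2ccc(C)cc2)[nH]c(=O)/c1=C\c1ccccc1OC` is not yet measured; it differs from compound 2 by 4-methylphenyl in place of 3-bromo-4-fluorophenyl on a double-bonded chain carbon bound to an aromatic carbon. Among the measured compounds shown here, with compound 2 lacking a number, the size and direction of the step to compound 3 cannot be taken from the two recorded points; the only anchor is compound 1 at 1200 nM, and the expectation is loose. Compound 3 is estimated in this assay at 5000 nM, within a range of 1000 nM to 30000 nM, with a real chance that only a limit is returned.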

Compound 3, half-maximal inhibitory concentration: "not active" (no number reported)
No number was reported for compound 3; the estimate stays without a comparison.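

In this assay, among these compounds, neither compound 2 nor compound 3 carries a number, so no step between them can be read. Open, going by these compounds, is how 3-bromo-4-fluorophenyl and 4-methylphenyl compare on the shared core. No measured evidence bears on this result.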